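A few compounds are considered here, and "the series" means these few. Any claim that something is new, unique, unknown or untested is made for them only; others in the source may bear on it.

The three measured compounds share one core and differ only in the aryl group attached to it. Compound 1 `COc1cc(-n2ncnc2-c2ccc(OC(C)C)cc2)cc(OC)c1OC` gives 650 nM in a functional assay on Jurkat cells (Homo sapiens) for antiproliferative activity, read by MTT assay, with a stated time of 72 h; on this read-out higher numbers stand for weaker inhibition and lower numbers for stronger inhibition. Compound 2 `COc1cc(-n2ncnc2-c2ccc(F)cc2)cc(OC)c1OC` reaches only a limit of this assay, > 10000 nM. Compound 3 `COc1cc(-n2ncnc2-c2cccc(F)c2)cc(OC)c1OC` likewise gives only a limit, > 10000 nM. Among the measured compounds shown here, the one readable step is an at least 15-fold higher number from compound 1 to compound 2 (1.18 log units; beyond the scatter). By contrast a step that the two limits leave unreadable from compound 2 to compound 3, since the limit of > 10000 nM in this assay, at which 2 of the 3 values shown sit, holds both ends of that pair. For the measured compounds named here, compound 3 therefore stands at the limit, with no number of its own, and compound 1 is the only member with a measured concentration.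

Compound 4 `COc1ccc(-c2ncnn2-c2cc(OC)c(OC)c(OC)c2)cc1` differs from compound 3 by 4-methoxyphenyl in place of 3-fluorophenyl on an aromatic carbon. The step that bears on this change is the one from isopropoxy to fluoro, an at least 15-fold higher number from compound 1 to compound 2 (1.18 log units; beyond the scatter), which is large. The methoxy group entering in compound 4 is an alkoxy group like the isopropoxy of compound 1, so a large move away from the limit, back toward the number seen for compound 1, is expected; the methoxy is shorter than isopropoxy, so the return is not assumed to be complete. The expected value for compound 4 is 1500 nM, within a range of 400 nM to 8000 nM. This corresponds to an estimated step of an at least 6.6-fold lower number from compound 3 to compound 4 (0.82 log units; beyond the scatter).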

Compound 4, half-maximal inhibitory concentration: 50 nM
For compound 4 the middle estimate is 30-fold (1.48 log units) above the measured one; measured number below the stated range.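

Among the compounds shown here, the place on an aromatic carbon of the five-membered aromatic ring with 3 nitrogen proves far more responsive than the earlier compounds showed: in this assay, 4-methoxyphenyl gives an at least 200-fold lower number from compound 3 to compound 4 (2.30 log units; beyond the scatter), and methoxy in place of fluoro gives an at least 200-fold lower number from compound 2 to compound 4 (2.30 log units; beyond the scatter). The earlier compounds showed only that isopropoxy outperforms fluoro, whereas methyl in place of isopropyl on the oxygen now gives a 13-fold lower number from compound 1 to compound 4 (1.11 log units; beyond the scatter), so among the two alkoxy groups shown the shorter one gives the lower number, and the bulk of the isopropyl group is not needed for activity in this series. Both steps from the fluoro compounds give only a minimum size, not a true one, because their starting points are limits and not numbers: the limit of > 10000 nM in this assay, at which 2 of the 4 values shown sit.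

As far as these compounds go, whether an ethoxy group, a hydroxyl or an amine in place of the methoxy would hold, raise or lower the number remains open. From the compounds shown here alone, compound 2 and compound 3 both stand at a limit, so the step between them cannot be read, and the effect of moving a substituent around the phenyl ring also remains open.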